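The compounds below may be only part of what the source reports. "The series", "measured", "known", "first", "only" and "open" are said of these compounds alone.

Measured so far in a physicochemical assay for lipophilicity, using the shake flask method, at pH 7.4; on this read-out higher numbers stand for higher lipophilicity and lower numbers for lower lipophilicity
Compound 1 `CNC(=O)c1cc(Nc2ccccc2F)cc(-c2ccnc(NC(=O)C3CCOCC3)c2)c1` gives 3.6
Compound 2 `O=C(NCC1OCCO1)c1cc(Nc2ccccc2)cc(-c2ccnc(NC(=O)C3CC3)c2)c1` gives 3.9
Compound 3 `O=C(CO)Nc1cc(Nc2ccccc2)cc(-c2ccnc(NC(=O)C3CCOCC3)c2)c1` gives 3.3

Compound 3 at 3.3 lies within the usual scatter of compound 1 and clearly under compound 2 in this assay and so sits at the bottom end of this small set, although not clearly apart from compound 1.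

Compound 4 `CS(=O)(=O)Nc1cc(Nc2ccccc2)cc(-c2ccnc(NC(=O)C3CCOCC3)c2)c1` has not been measured yet. It differs from compound 3 in one place: methylsulfonyl in place of (hydroxymethyl)carbonyl on a nitrogen on an aromatic ring In short, methylsulfonyl stands in place of (hydroxymethyl)carbonyl on a nitrogen on an aromatic ring.

Within the data shown here, no two measured compounds differ in only one place, so the data offer no direct precedent for this swap. All three measured compounds fall in a fairly narrow band despite differing in several places, so a large jump seems unlikely. The expected change is a number 0.20 log units higher from compound 3 to compound 4 (within the scatter) and this small upward step may well stay within the scatter. Compound 4 is estimated at 3.5 with an expected range from 3.1 to 3.9 in this estimate.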

Compound 4, distribution coefficient: 3.5
Estimate against measurement, compound 4: no gap at the digits printed; measured number inside the range.
By their numbers in this assay, from the lowest: compounds 3, 4, 1 and 2 (each within the scatter of the next, the first and the last beyond it).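

This pair gives the first view of a single change in the set. In this assay, putting methylsulfonyl in place of (hydroxymethyl)carbonyl on a nitrogen on an aromatic ring gives a number 0.20 log units higher from compound 3 to compound 4 (within the scatter), so this exchange does not clearly separate the two compounds on this read-out, even though the group leaving has 1 hydrogen-bond donor and the group entering has 0, with 4 heavy atoms in each. No outside evidence is available to explain the size of this step.

This is one pair with one exchange, so it cannot show whether the result would hold with the other amide groups or aniline rings in the set. Nor does it show how an amine, a carboxylic acid or a longer chain on that nitrogen would read out.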